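The source may report more compounds than this note shows. Statements on the series, on what has been measured and on what is new or still open speak of the compounds shown alone.

Compound 1 `O=C(NCc1cc(C(F)(F)F)nn1-c1cccc(Cl)c1)Nc1cccc2[nH]ncc12` is the reference point of the series. In an assay on CHO-K1 cells for antagonist activity at transient receptor potential cation channel subfamily V member 1 (Homo sapiens), read by FLIPR and calcium flux, with a stated time of 6 min (a higher number here means a weaker inhibitor, a lower number a stronger inhibitor), compound 1 gives 0.9 nM, the lowest of the two numbers in hand. Going by the values given here, the only measured comparison is with compound 2 `CC(=O)n1ncc2c(NC(=O)NCc3cc(C(F)(F)F)nn3-c3cccc(Cl)c3)cccc21`, which in this assay gives 17.4 nM; the step of a 19-fold higher number from compound 1 to compound 2 (1.29 log units; beyond the scatter) is acetyl in place of hydrogen on an aromatic nitrogen, and it changes a different part of the shared core from the one that is varied next.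

Compound 3 `O=C(NCc1cc(C(F)(F)F)nn1-c1ccc(C(F)(F)F)cc1)Nc1cccc2[nH]ncc12` has not yet been measured. It differs from compound 1 in one place: 4-(trifluoromethyl)phenyl in place of 3-chlorophenyl on an aromatic nitrogen. Among the compounds with values here, no measured step touches this aryl group, so the acetyl step from compound 1 to compound 2 gives no guide to the direction or size of the change; it only shows that the series is sensitive to changes at the other end of the core.

Within the data shown here, with no bearing step, the expectation for compound 3 is a number close to that of compound 1, with a step of a 2.0-fold higher number from compound 1 to compound 3 (0.30 log units; within the scatter) that is expected to stay within or only slightly beyond the scatter. Compound 3 is therefore estimated at 1.8 nM in this assay, with a range of 0.4 nM to 8 nM.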

Compound 3, inhibition constant: 3.8 nM
Estimate against measurement, compound 3: 2.1-fold (0.32 log units) below, within the range that was stated.
By their numbers in this assay, from the lowest: compound 1; then compound 3; then compound 2.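

Going by these compounds alone, at this aryl group on the aromatic nitrogen, the series responds to a change for the first time in this assay, with a 4.2-fold higher number from compound 1 to compound 3 (0.63 log units; beyond the scatter) when 4-(trifluoromethyl)phenyl replaces 3-chlorophenyl. The larger aryl group, at 10 heavy atoms against 7, still leaves compound 3 at 3.8 nM, and this step is smaller than the one at the other end of the shared core, a 19-fold higher number from compound 1 to compound 2 (1.29 log units; beyond the scatter), so both ends of compound 1 now have a measured sensitivity to change. No measurement in hand gives a reason for the rise in the number at this aryl group.

The substituent and its place on the phenyl ring change together in this single step, so the compounds shown leave open how much of the difference belongs to each, a question that 4-chlorophenyl or 3-(trifluoromethyl)phenyl would separate. Also open is how this aryl group responds to an amine or a carboxylic acid in place of the halogen-bearing substituents, as every aryl group shown carries chlorine or fluorine.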